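The compounds below may be only part of what the source reports. "The series", "measured", "known", "first", "only" and "open" are said of these compounds alone.

Three compounds have been measured:
compound 1, `O=C(O)CNc1cccc(CNc2cc(C(F)(F)F)cc3[nH]ncc23)c1`, 8%
compound 2, `FC(F)(F)c1cccc(CNc2cc(C(F)(F)F)cc3[nH]ncc23)c1`, 49%
compound 3, `O=C(O)c1cccc(CNc2cc(C(F)(F)F)cc3[nH]ncc23)c1`, 17%

In an assay for inhibition of Indoleamine 2,3-dioxygenase 1 (Homo sapiens), with stated times of 10 min and 60 min, tested at 100 uM (on this read-out higher numbers stand for a stronger effect at the one concentration tested and lower numbers for a weaker effect), compound 3 stands second highest of the three. Its nearest neighbour gives a number 9 percentage points higher from compound 1 to compound 3 (within the scatter), and its furthest gives a number 32 percentage points lower from compound 2 to compound 3 (beyond the scatter). Compound 4, `CNC(=O)c1cccc(CNc2cc(C(F)(F)F)cc3[nH]ncc23)c1`, is not yet measured. It differs from compound 3 in one place: methylamino in place of hydroxy on a carbonyl carbon. Read one bond further out, this is carboxy to methylcarbamoyl.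

For the measured compounds named here, none of the measured steps makes this particular change. Going by the values given here, the only step that touches the carboxy group is a number 32 percentage points lower from compound 2 to compound 3 (beyond the scatter), and that step exchanges the whole group rather than one part of it. The step of a number 9 percentage points higher from compound 1 to compound 3 (within the scatter) shows that the (carboxymethyl)amino group gives a value within the scatter of compound 3. Among the compounds with values here, with no direct precedent, only a small change is expected. The estimated step is a number 5 percentage points higher from compound 3 to compound 4 (within the scatter). Compound 4 is therefore estimated at 22%, with a range from 5% to 45%.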

Compound 4, a percentage reported as inhibition, at one concentration (the size of the read-out at that concentration, not a potency): 46%
For compound 4 the middle estimate is 24 percentage points below the measured one; measured number above the stated range.
By their numbers in this assay, from the lowest: compounds 1 and 3 (each within the scatter of the next); then compounds 4 and 2 (each within the scatter of the next).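

In this assay, for the compounds shown here, replacing hydroxy with methylamino on the carbonyl carbon gives a number 29 percentage points higher from compound 3 to compound 4 (beyond the scatter), so altering only part of the carboxy group can matter here, whereas the earlier steps exchanged whole groups. On this aromatic carbon, methylcarbamoyl and trifluoromethyl cannot be told apart, with a number 3 percentage points lower from compound 2 to compound 4 (within the scatter), while the change from the (carboxymethyl)amino group gives a number 38 percentage points higher from compound 1 to compound 4 (beyond the scatter). Nothing available explains these differences.

As far as these compounds go, it remains open whether the methyl group contributes to the higher number or whether a simple amide, with an unsubstituted amino group on the carbonyl carbon, would do the same. A dimethylamino or ethylamino group in the same place, or a methyl ester, would show how far this tolerance extends.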